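Cyclohexyl for tert-butyl on a spiro-piperidine benzamide series

A few compounds are considered here, and "the series" means these few. Any claim that something is new, unique, unknown or untested is made for them only; others in the source may bear on it.

Of the compounds shown here, three of a shared core have been measured in an assay on HEK293 cells for displacement of a labelled ligand from NPC1-like intracellular cholesterol transporter 1 (Homo sapiens); a lower number here means a stronger inhibitor, a higher number a weaker inhibitor. Compound 1 `O=C(CN1CN(c2ccccc2)C2(CCN(C(=O)c3ccc(C4CCCCC4)cc3)CC2)C1=O)N1CCC(CO)CC1` gives 1100 nM, and compound 2 `O=C(CN1CN(c2ccccc2)C2(CCN(C(=O)c3ccc(C4CCCCC4)cc3)CC2)C1=O)N1CCCCC1` gives 1100 nM. Compound 3 `CCOC(=O)C1CCCN(C(=O)CN2CN(c3ccccc3)C3(CCN(C(=O)c4ccc(C(C)(C)C)cc4)CC3)C2=O)C1` gives 8200 nM, the highest of the three numbers, beyond the scatter above both compound 1 and compound 2. Going by the values given here, compound 3 differs from those two in two places at once, so no single step ties it to them. Among the compounds with values here, the only single-place step on record, no change at the digits printed from compound 1 to compound 2 (within the scatter), shows that the amide tail can be altered without moving this assay. Compound 4 `CCOC(=O)C1CCCN(C(=O)CN2CN(c3ccccc3)C3(CCN(C(=O)c4ccc(C5CCCCC5)cc4)CC3)C2=O)C1` differs from compound 3 by cyclohexyl in place of tert-butyl on an aromatic carbon. Within the data shown here, no measured step covers this change; the one indirect pointer is that compound 1 and compound 2, both bearing cyclohexyl, stand well below compound 3 while the tail itself appears neutral. Compound 4 is therefore expected to fall by a 5.5-fold lower number from compound 3 to compound 4 (0.74 log units; beyond the scatter), towards the cyclohexyl pair, with an estimate of 1500 nM and a range from 600 nM to 5000 nM.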

Compound 4, half-maximal inhibitory concentration: 4200 nM
Beside the measured number, compound 4's estimate is 2.8-fold (0.45 log units) below it; the range from low to high includes it.
By their numbers in this assay, from the lowest: compounds 1 and 2 (each within the scatter of the next); then compounds 4 and 3 (each within the scatter of the next).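

In this assay, the para position of the benzamide does not separate the two groups: placing cyclohexyl where tert-butyl stood gives a step within the scatter (a 2.0-fold lower number from compound 3 to compound 4 (0.29 log units; within the scatter)). With cyclohexyl held constant, the amide tail does register, unlike the hydroxymethyl change seen earlier, since ethoxycarbonyl in place of hydrogen gives one modest step (a 3.8-fold higher number from compound 2 to compound 4 (0.58 log units; beyond the scatter)) and the exchange of the whole tail gives another (a 3.8-fold higher number from compound 1 to compound 4 (0.58 log units; beyond the scatter)). Nothing on record accounts for these steps.

On these data alone, it remains open whether a phenyl ring or a methoxy group at the same aromatic carbon would read any differently from these two carbon groups. As far as these compounds go, it is also open whether a carboxylic acid or a primary amide in place of the ethoxycarbonyl would keep or remove the step seen with the ester.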